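The source may hold more compounds than are shown below. What is called first, only, known or untested is meant among the compounds shown, and "the series" means these compounds.

Measured so far:
compound 1, `COc1cccc(/C=C/C(=O)NCCn2c(C)cc3ccccc32)c1` — 29.2 nM
compound 2, `COc1ccccc1/C=C/C(=O)NCCn1c(C)cc2ccccc21` — 13 nM

Both numbers come from an assay on C6 cells for antagonist activity at prostaglandin E2 receptor EP2 subtype (Homo sapiens), read by TR-FRET, with stated times of 10 min and 40 min, tested at 1 uM; on this read-out lower numbers stand for stronger inhibition and higher numbers for weaker inhibition. For the measured compounds named here, compound 2 gives the lower of the two numbers; the one measured step, a 2.2-fold lower number from compound 1 to compound 2 (0.35 log units; beyond the scatter), is the only guide to how the position of the methoxy group on this phenyl ring matters, and it is modest.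

Compound 3, `COc1ccc(/C=C/C(=O)NCCn2c(C)cc3ccccc32)cc1`, has not yet been measured. Relative to compound 2 the change is 4-methoxyphenyl in place of 2-methoxyphenyl on a double-bonded chain carbon bound to a double-bonded chain carbon. Going by the values given here, no measured pair covers the 4-methoxyphenyl group, so the step from compound 1 to compound 2 bears only indirectly: it shows that moving the methoxy group between two positions changes the number by a modest amount, in either direction as far as the data go.

Compound 3 is therefore expected to land near compound 1 or compound 2 rather than far from both, with a step estimated at a 2.3-fold higher number from compound 2 to compound 3 (0.36 log units; beyond the scatter). The estimate for compound 3 in this assay is 30 nM, with a range from 10 nM to 90 nM.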

Compound 3, antagonist equilibrium constant: 16.5 nM
Beside the measured number, compound 3's estimate is 1.8-fold (0.26 log units) above it; low and high end bracket the measured number.
By their numbers in this assay, from the lowest: compounds 2, 3 and 1 (each within the scatter of the next, the first and the last beyond it).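

With the 4-methoxyphenyl group on the double-bonded chain carbon, the three methoxy placements can now be compared in this assay, and both new steps, a 1.3-fold higher number from compound 2 to compound 3 (0.10 log units; within the scatter) and a 1.8-fold lower number from compound 1 to compound 3 (0.25 log units; within the scatter), lie within the scatter. For the compounds shown here, compound 3 therefore cannot be separated from either compound 1 or compound 2, and the only step beyond the scatter remains the modest one between those two. No placement of the methoxy group stands apart from both of the others, so this change has only a small influence on the number across these three compounds.

No available evidence accounts for these small differences. From the compounds shown here alone, what stays open is whether another group on this phenyl ring, such as a nitrile, an amine or a carboxylic acid, would shift the number further than the methoxy placements do, and how much change the shared core tolerates.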